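Swapping 4-nitrophenyl for pyridin-3-yl

The source may hold more compounds than are shown below. What is called first, only, known or untested is meant among the compounds shown, and "the series" means these compounds.

Measured in a functional assay on MCF7 cells (Homo sapiens) for antiproliferative activity, read by MTT assay, with a stated time of 48 h; a lower number here means a stronger inhibitor, a higher number a weaker inhibitor:
- Compound 1 `CC(=O)N1N=C(c2ccc3ccccc3c2)OC1c1cccc(Br)c1`: 2.34 ug/mL
- Compound 2 `CC(=O)N1N=C(c2ccc3ccccc3c2)OC1c1ccc(Br)cc1`: 5.07 ug/mL
- Compound 3 `CC(=O)N1N=C(c2ccc3ccccc3c2)OC1c1ccc([N+](=O)[O-])cc1`: 7.59 ug/mL

Compound 3 stands at the upper end of these numbers, with a 3.2-fold higher number from compound 1 to compound 3 (0.51 log units; beyond the scatter) and a 1.5-fold higher number from compound 2 to compound 3 (0.18 log units; within the scatter). Compound 4 `CC(=O)N1N=C(c2ccc3ccccc3c2)OC1c1cccnc1` carries pyridin-3-yl in place of 4-nitrophenyl on a saturated ring carbon. For the measured compounds named here, no measured compound carries pyridin-3-yl, so the evidence is indirect. The closest guides are other changes to the same aromatic group, namely a 2.2-fold higher number from compound 1 to compound 2 (0.34 log units; beyond the scatter) and the step from bromo to nitro already given. These steps are modest or within the scatter, so only a small shift is expected in this assay. The estimated step is a 1.2-fold higher number from compound 3 to compound 4 (0.07 log units; within the scatter), which is not expected to lie beyond the scatter. For compound 4 the estimate is 9 ug/mL, with an expected range of 3 ug/mL to 27 ug/mL.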

Compound 4, half-maximal inhibitory concentration: 2.61 ug/mL
Beside the measured number, compound 4's estimate is 3.4-fold (0.54 log units) above it; the measured number lies below the stated range.
By their numbers in this assay, from the lowest: compounds 1, 4, 2 and 3 (each within the scatter of the next, the first and the last beyond it).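

At this saturated ring carbon in this assay, pyridin-3-yl is the first group shown without a bromo or nitro substituent, and replacing 4-nitrophenyl with it gives a 2.9-fold lower number from compound 3 to compound 4 (0.46 log units; beyond the scatter), the only new step beyond the scatter. Against the two bromophenyl compounds, the steps are a 1.9-fold lower number from compound 2 to compound 4 (0.29 log units; within the scatter) and a 1.1-fold higher number from compound 1 to compound 4 (0.05 log units; within the scatter), so both lie within the scatter and a ring nitrogen does about as well here as a bromo group on a carbon-only ring. Nothing measured here explains this result.

The compounds shown leave open whether pyridin-2-yl or pyridin-4-yl would match pyridin-3-yl. They also leave open how a phenyl ring carrying an amine or a carboxylic acid would fare at this carbon.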